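One Carbon Longer: From Compound 2 to Compound 3

The source may hold more compounds than are shown below. What is called first, only, known or untested is meant among the compounds shown, and "the series" means these compounds.

Of the compounds shown here, two have so far been tested in a functional assay on the whole organism (stomach) with Rattus norvegicus as the target; on this read-out higher numbers stand for an effect only at larger amounts of compound and lower numbers for an effect already at smaller amounts. Compound 1 `O=c1cccnn1CCC(=S)N1CCCC1` gives in this assay only the limit of > 100 mg/kg, not a number. Compound 2 `Cc1ccc(=O)n(CCCCCC(=N)S)n1` likewise gives in this assay only the limit of > 100 mg/kg. Within the data shown here, both results sit at the limit of > 100 mg/kg in this assay, at which 2 of the 2 values shown sit, so no step between measured compounds can be read from them, and compound 2 stands simply at that limit, with nothing to rank it against.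

Compound 3 `Cc1ccc(=O)n(CCCCCCC(=N)S)n1` has not been measured yet. It differs from compound 2 in a group of 4 heavy atoms (2 carbon, 1 nitrogen, 1 sulfur; no ring) in place of a group of 3 heavy atoms (1 carbon, 1 nitrogen, 1 sulfur; no ring), on a saturated chain carbon, five bonds along the chain from an aromatic nitrogen. Among the measured compounds shown here, no measured pair shows what a change of this kind does in this assay, so the expectation for compound 3 rests only on where compound 2 sits. The step is expected to be a step that the limit leaves unreadable from compound 2 to compound 3, none beyond the usual scatter. The estimated value for compound 3 in this assay is therefore 150 mg/kg, with an expected range from 60 mg/kg to 400 mg/kg, and most likely the assay would again report only a limit rather than a number.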

Compound 3, dose for half-maximal effect: > 100 mg/kg
Compound 3 gave a limit, no number; the forecaster's own chance of this, stated with the estimate: 80%; the middle value does not contradict the limit.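

Compound 2 and compound 3 both give only a limit in this assay, not a number, so no step between them can be read: the limit of > 100 mg/kg in this assay, at which 3 of the 3 values shown sit.

The compounds shown leave open whether any of them has an effect that this read-out can put a number on, and whether the group of 4 heavy atoms in compound 3 makes any difference to it.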